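The compounds below may be only part of what the source reports. "The series", "measured", "known", "first", "only" and "open" are said of these compounds alone.

Measured in a functional assay on FaDu cells (Homo sapiens) for cytotoxicity, read by MTT assay, with a stated time of 72 h; on this read-out higher numbers stand for lower toxicity in this test and lower numbers for higher toxicity in this test:
- compound 1 `COc1ccc2c(c1)c(C(=O)C(=O)Nc1ccc(OC)nc1)cn2C(C)C`: > 10000 nM, a limit of the assay
- compound 2 `COc1ccc(NC(=O)C(=O)c2cn(C(C)C)c3ccccc23)cn1`: 85 nM

Compound 1 has no exact number: its reading is the limit of > 10000 nM in this assay, at which 1 of the 2 values shown sits. Compound 3 `COCCn1cc(C(=O)C(=O)Nc2ccc(OC)nc2)c2cc(OC)ccc21` keeps the core of compound 1, with its methoxy on an aromatic carbon, and carries 2-methoxyethyl in place of isopropyl on an aromatic nitrogen.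

Among the compounds with values here, the only measured step is an at least 110-fold lower number from compound 1 to compound 2 (2.07 log units; beyond the scatter). It is large, but it removes that methoxy and leaves the isopropyl in place, so it bears only indirectly on this change. Within the data shown here, no measured step alters the group on the nitrogen. Compound 3 retains the methoxy that compound 2 lacks, so the low value of compound 2, 85 nM, is not expected to carry over. No step beyond the scatter is expected in this assay, and a further reading at the limit is the likelier result. The expected step is a number no higher from compound 1 to compound 3 (the limit leaves the size open). The estimate for compound 3 is 10000 nM, with an expected range of 2000 nM to 30000 nM.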

Compound 3, concentration lethal to 50% of the cells: > 10000 nM
Compound 3 gave a limit, no number (the forecaster's own chance of this, stated with the estimate: 65%); the middle value sits exactly at the limit.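

Compound 1 and compound 3 both sit at a limit, not a number, in this assay, so no step between them can be read: the limit of > 10000 nM in this assay, at which 2 of the 3 values shown sit.

On these data alone, what 2-methoxyethyl in place of isopropyl does to the reading stays open, both on the core of compound 1 and on compound 2, which lacks that methoxy.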